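Phenylsulfonyl in Place of a Benzyl Group on the Amine

The source may hold more compounds than are shown below. What is called first, only, known or untested is meant among the compounds shown, and "the series" means these compounds.

Measured compounds:
Compound 1 `c1ccc(C2CCCCN2C2CCN(CCCc3c[nH]c4ccc(-n5cnnc5)cc34)CC2)cc1`: 1.9 nM
Compound 2 `CN(Cc1ccc(S(C)(=O)=O)cc1)C1CCN(CCCc2c[nH]c3ccc(-n4cnnc4)cc23)CC1`: 18 nM
Compound 3 `CC(=O)Nc1ccc(CNC2CCN(CCCc3c[nH]c4ccc(-n5cnnc5)cc34)CC2)cc1`: 3 nM

In an assay on CHO cells for displacement of a labelled ligand from 5-hydroxytryptamine receptor 1D (Homo sapiens) (on this read-out lower numbers stand for stronger inhibition and higher numbers for weaker inhibition), compound 2 gives 18 nM, the highest of the three numbers. Compound 3 gives 3 nM, and compound 1 gives 1.9 nM; both gaps from compound 2 are beyond the scatter, so compound 2 is the weakest of the three. Compound 4 `CN(C1CCN(CCCc2c[nH]c3ccc(-n4cnnc4)cc23)CC1)S(=O)(=O)c1ccccc1` differs from compound 2 in one place: phenylsulfonyl in place of 4-(methylsulfonyl)benzyl on an amine nitrogen. For the measured compounds named here, no single-change step between measured compounds exists here to show what such a swap does, so the expected step rests on the structures alone. Compound 4 is estimated at 30 nM, within 9 nM to 100 nM. The expected step of a 1.7-fold higher number from compound 2 to compound 4 (0.22 log units; within the scatter) is a mild weakening, barely beyond the scatter.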

Compound 4, half-maximal inhibitory concentration: 1.5 nM
Compound 4: the middle estimate sits 20-fold (1.30 log units) above what was measured; the measured number lies below the stated range.
By their numbers in this assay, from the lowest: compounds 4, 1 and 3 (each within the scatter of the next); then compound 2.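

In this assay, phenylsulfonyl in place of 4-(methylsulfonyl)benzyl on this amine nitrogen gives a 12-fold lower number from compound 2 to compound 4 (1.08 log units; beyond the scatter), so this position responds strongly to the group it carries. The two groups have the same donor and acceptor counts and no net charge, yet the change is large. Nothing available accounts for the size of this step. Going by these compounds, it remains open whether the step follows from the sulfonyl sitting directly on the nitrogen or from the loss of the methylsulfonyl group; a plain benzyl or a benzoyl group here would separate the two.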